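Bromo to fluoro on the shared core

The compounds below may be only part of what the source reports. "The series", "measured", "known", "first", "only" and "open" are said of these compounds alone.

Measured in a functional assay on BT-549 cells (Homo sapiens) for cytotoxicity, read by MTT assay, with a stated time of 48 h; a higher number here means a weaker inhibitor, a lower number a stronger inhibitor:
- compound 1 `CCn1c(/C=C2/C(=O)Nc3ccc(F)cc32)nc2ccccc21`: > 50000 nM (a limit)
- compound 2 `Cn1c(/C=C2/C(=O)Nc3ccc([N+](=O)[O-])cc32)nc2ccccc21`: "not determined" (no result reported)
- compound 3 `Cn1c(/C=C2/C(=O)Nc3ccc(Br)cc32)nc2ccccc21`: > 50000 nM (a limit)

Compound 3 gives > 50000 nM, which is a limit and not a number. Within the data shown here, the series so far stands at the limit of > 50000 nM in this assay, at which 2 of the 3 values shown sit. Compound 4 `Cn1c(/C=C2/C(=O)Nc3ccc(F)cc32)nc2ccccc21` carries fluoro in place of bromo on an aromatic carbon. Compound 1 also carries the fluoro group and gives > 50000 nM, again a limit. No shift beyond the scatter is expected in this assay, and the estimated step of a number no higher from compound 3 to compound 4 (the limit leaves the size open) is small. For compound 4 the expected value is 50000 nM, with an estimated range of 20000 nM to 100000 nM.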

Compound 4, half-maximal inhibitory concentration: 26900 nM
Beside the measured number, compound 4's estimate is 1.9-fold (0.27 log units) above it, and the stated range covers the measured number.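

Among these compounds, compound 4 is the first compound in this assay to read as a number and not a limit. Fluoro in place of bromo on the aromatic carbon gives an at least 1.8-fold lower number from compound 3 to compound 4 (0.26 log units; that floor lies within the scatter), and hydrogen in place of methyl on the saturated chain carbon bound to the aromatic nitrogen gives an at least 1.8-fold lower number from compound 1 to compound 4 (0.26 log units; that floor lies within the scatter). Neither floor shows a change beyond the scatter, and the true size of both steps stays open: the limit of > 50000 nM in this assay, at which 2 of the 4 values shown sit.

Open, as far as these compounds go, is how an amine or a carboxylic acid on this aromatic carbon would read. Also open, from the compounds shown here alone, is how a propyl chain on the aromatic nitrogen would read.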